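Thioureas bearing a trifluoromethylphenyl arm: cytotoxicity notes

A few compounds are considered here, and "the series" means these few. Any claim that something is new, unique, unknown or untested is made for them only; others in the source may bear on it.

Measured so far:
compound 1 `Fc1ccccc1NC(=S)Nc1cccc(C(F)(F)F)c1` — 47000 nM
compound 2 `COc1cccc(NC(=S)Nc2cccc(C(F)(F)F)c2)c1` — 26000 nM

Going by the values given here, in an ADME assay on MT4 cells (Homo sapiens) for cytotoxicity (a lower number here means that less compound is tolerated, a higher number that more compound is tolerated), compound 1 gives 47000 nM, the higher of the two numbers so far, while compound 2 gives 26000 nM; the gap between them lies within the scatter, so no order between the two is drawn. Among the compounds with values here, no step between measured compounds is available to guide the next change.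

Compound 3 `CC(=O)NC(=S)Nc1cccc(C(F)(F)F)c1` is not yet measured. It differs from compound 1 by acetyl in place of 2-fluorophenyl on an amide-type nitrogen. Within the data shown here, no measured pair shows what this change does to the tolerated concentration, so the expectation is a step of small size, if any, and more likely toward a higher tolerated concentration than a lower one. The expected step is a 1.4-fold higher number from compound 1 to compound 3 (0.14 log units; within the scatter), which stays near the scatter. Compound 3 is thus estimated at 65000 nM, with a range from 25000 nM to 170000 nM.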

Compound 3, half-maximal cytotoxic concentration: > 100000 nM
Compound 3: no number, only a limit (the forecaster's own chance of this, stated with the estimate: 30%); at least 1.5-fold (0.18 log units) between middle value and limit.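

In this assay compound 3 gives > 100000 nM, which is a limit of the assay and not a number. Acetyl in place of 2-fluorophenyl on an amide-type nitrogen gives an at least 2.1-fold higher number from compound 1 to compound 3 (0.32 log units; beyond the scatter), the first step in the series that can be read; it shows that an aromatic ring is not needed at this nitrogen for the compound to be tolerated, and that this change moves the read-out beyond the scatter. The step is only a minimum, and its full size stays unread: the limit of > 100000 nM in this assay, at which 1 of the 3 values shown sits.

The compounds shown cannot separate the loss of the ring from the arrival of the carbonyl. A benzoyl group, which carries both, or a propyl chain, which carries neither, would bear on that question.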